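Amide variation on a shared sulfonylpiperazine core

The compounds below may be only part of what the source reports. "The series", "measured", "known", "first", "only" and "open" are said of these compounds alone.

Compounds 1, 2 and 3 share one core and differ only in the amide part. Compound 1 is `CCN(CC)C(=O)C(C)N1CCN(S(=O)(=O)c2ccc(C(C)(C)C)cc2)CC1`. In an ADME assay on HepG2 cells (Homo sapiens) for inhibition, with a stated time of 48 h (a higher number here means that more compound is needed for the effect, a lower number that less compound is needed), compound 1 gives > 40000 nM, which is a limit of the assay and not a number. Compound 2 is `CC(C(=O)N1CCCCC1)N1CCN(S(=O)(=O)c2ccc(C(C)(C)C)cc2)CC1`. In this assay compound 2 gives > 40000 nM, again a limit. Compound 3 is `CC(C(=O)N1CCC(F)(F)CC1)N1CCN(S(=O)(=O)c2ccc(C(C)(C)C)cc2)CC1`. In this assay compound 3 gives > 40000 nM, likewise a limit. The steps a step that the two limits leave unreadable from compound 1 to compound 2, a step that the two limits leave unreadable from compound 1 to compound 3 and a step that the two limits leave unreadable from compound 2 to compound 3 cannot be read because of the limit of > 40000 nM in this assay, at which 3 of the 3 values shown sit. Compound 3 thus stands at the same limit as the two other values, and nothing orders the three.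

Compound 4 is `CC(C(=O)N1CCC(C)(C)CC1)N1CCN(S(=O)(=O)c2ccc(C(C)(C)C)cc2)CC1`. The change from compound 3 is 4,4-dimethylpiperidin-1-yl in place of 4,4-difluoropiperidin-1-yl on a carbonyl carbon. Within the data shown here, no measured step touches this exchange directly; the nearest, a step that the two limits leave unreadable from compound 2 to compound 3, is itself unreadable. With every measured value sitting at the limit, no step beyond the scatter is expected in this assay in either direction, and the expected step that the limit leaves unreadable from compound 3 to compound 4 reflects that alone. Compound 4 is therefore estimated at 60000 nM, within 25000 nM to 150000 nM, and is most likely to be reported once more as a limit.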

Compound 4, half-maximal effective concentration: > 40000 nM
Compound 4 gave a limit, no number; the forecaster's own chance of this, stated with the estimate: 80%; the middle value is on the limit's open side.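

The steps from compound 1, compound 2 and compound 3 to compound 4 cannot be read, because all of them run into one shared limit: the limit of > 40000 nM in this assay, at which 4 of the 4 values shown sit.

The compounds shown leave open whether any amide on the shared core gives a measurable half-maximal effective concentration in this assay, and how these four amides would order.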